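Chloro for Fluoro in a Series Sitting at the Assay Limit

The source may report more compounds than this note shows. Statements on the series, on what has been measured and on what is new or still open speak of the compounds shown alone.

Compound 1 `COc1ccc([C@@H]2c3c(OC)cc(OC)cc3/C(=C/c3ccc(F)cc3)[C@H]2c2cc(OC)cc(OC)c2)cc1`: in a functional assay on RAW264.7 cells (Mus musculus) for inhibition, with stated times of 2 h and 24 h (on this read-out lower numbers stand for stronger inhibition and higher numbers for weaker inhibition), compound 1 gives > 200000 nM, which is a limit of the assay and not a number.
Compound 2 `COc1ccc([C@@H]2c3c(OC)cc(OC)cc3/C(=C/c3ccc(Cl)cc3)[C@H]2c2cc(OC)cc(OC)c2)cc1`: in this assay compound 2 gives > 200000 nM, again a limit.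
Compound 3 `COc1ccc([C@@H]2c3c(OC)cc(OC)cc3C(C(O)c3ccc(F)cc3)[C@H]2c2cc(OC)cc(OC)c2)cc1`: in this assay compound 3 gives > 200000 nM, also a limit.

Compound 2 differs from compound 1 by chloro in place of fluoro on an aromatic carbon. The step that the two limits leave unreadable from compound 1 to compound 2 cannot be sized, since both values are limits. Compound 3 and compound 1 differ in their cores; that difference is not broken down here.

Compound 4 `COc1ccc([C@@H]2c3c(OC)cc(OC)cc3C(C(O)c3ccc(Cl)cc3)[C@H]2c2cc(OC)cc(OC)c2)cc1` has not yet been measured. It differs from compound 3 by chloro in place of fluoro on an aromatic carbon, the same change as that between compound 1 and compound 2, made at the same kind of place on the other core. Because every measured value in this series sits at the limit of > 200000 nM in this assay, at which 3 of the 3 values shown sit, the expected step that the limit leaves unreadable from compound 3 to compound 4 from compound 3 to compound 4 rests on nothing more than that shared limit and is expected to be flat. Compound 4 is therefore estimated at 300000 nM in this assay, with an expected range from 100000 nM to 1500000 nM, most probably reported once more as a limit.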

Compound 4, half-maximal inhibitory concentration: > 200000 nM
Compound 4 ended at the assay's limit; the forecaster's own chance of this, stated with the estimate: 85%; the middle value is on the limit's open side.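

In this assay compound 4 gives > 200000 nM, a limit of the assay and not a number. Compound 3 gives > 200000 nM, also a limit. No step can be read between compound 3 and compound 4. The compounds shown leave open whether chloro, fluoro or either core has any bearing on inhibition, as every value stands at one limit: the limit of > 200000 nM in this assay, at which 4 of the 4 values shown sit.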